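The source may report more compounds than this note shows. Statements on the series, on what has been measured and on what is new or still open speak of the compounds shown alone.

Three nucleoside analogues carrying a substituted benzyl group on a sulfur atom attached to the shared core have been measured in an assay on K562 cells for displacement of a labelled ligand from Equilibrative nucleoside transporter 1 (Homo sapiens); a lower number here means a stronger inhibitor, a higher number a weaker inhibitor. Compound 1 `OC[C@H]1O[C@@H](n2cnc3c(SCc4cccc(Br)c4)ncnc32)[C@H](O)[C@@H]1O` gives 20.5 nM, compound 2 `OC[C@H]1O[C@@H](n2cnc3c(SCc4ccc(Br)cc4)ncnc32)[C@H](O)[C@@H]1O` gives 9.98 nM, and compound 3 `OC[C@H]1O[C@@H](n2cnc3c(SCc4ccccc4Cl)ncnc32)[C@H](O)[C@@H]1O` gives 99.5 nM. Compound 3 therefore stands highest of the three numbers and is the weakest inhibitor in this assay: its nearest neighbour is compound 1 (a 4.9-fold higher number from compound 1 to compound 3 (0.69 log units; beyond the scatter)) and the gap to compound 2 is wider still (a 10-fold higher number from compound 2 to compound 3 (1.00 log units; beyond the scatter)). Moving the bromine from the 3-position to the 4-position also helped, as seen in a 2.1-fold lower number from compound 1 to compound 2 (0.31 log units; beyond the scatter).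

Compound 4 `OC[C@H]1O[C@@H](n2cnc3c(SCc4ccc(Cl)cc4)ncnc32)[C@H](O)[C@@H]1O` differs from compound 3 by a single change: 4-chlorophenyl in place of 2-chlorophenyl on a saturated chain carbon bound to a sulfur. The step from compound 2 to compound 3 bears most directly on it, since it is essentially the same move run in reverse, with chlorine in place of bromine; the step from compound 1 to compound 3 points the same way. Compound 4 is accordingly expected to give a clearly lower number than compound 3 in this assay, a step of about a 7.7-fold lower number from compound 3 to compound 4 (0.88 log units; beyond the scatter), kept slightly smaller than the step seen between compound 2 and compound 3 as the halogen here is chlorine rather than bromine. The estimate for compound 4 is 13 nM, with a range from 5 nM to 35 nM.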

Compound 4, inhibition constant: 14.2 nM
Compound 4: the middle estimate sits 1.1-fold (0.04 log units) below what was measured, and the stated range covers the measured number.
By their numbers in this assay, from the lowest: compounds 2, 4 and 1 (each within the scatter of the next, the first and the last beyond it); then compound 3.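

With the halogen held as chlorine, changing 2-chlorobenzyl to 4-chlorobenzyl on the sulfur gives a 7.0-fold lower number from compound 3 to compound 4 (0.85 log units; beyond the scatter) in this assay, so the place of the halogen alone accounts for a step of this size, whereas the earlier step from compound 2 to compound 3 changed the halogen as well. Chloro in place of bromo on the same aromatic carbon gives a 1.4-fold higher number from compound 2 to compound 4 (0.15 log units; within the scatter), and 4-chlorophenyl in place of 3-bromophenyl gives a 1.4-fold lower number from compound 1 to compound 4 (0.16 log units; within the scatter); both lie within the scatter, so in this set the choice of chlorine or bromine does not separate compound 4 from compound 2, and compound 4 cannot be told apart from compound 1. Nothing available here gives a reason for the large step from the 2-chlorobenzyl to the 4-chlorobenzyl compound.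

Still open, on these data alone, is whether a 2-bromobenzyl group would give a number as high as that of compound 3, and whether a 3-chlorobenzyl group would match compound 1. As far as these compounds go, it is also open whether a 4-methoxybenzyl group, a 4-nitrobenzyl group or a phenethyl group on the sulfur would keep the number this low.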